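Trihydroxyphenyl in place of chlorophenyl on a sulfonyl enone

This account rests on a few compounds, and the source may have more. Where it says the series, first, only, none or still open, it means among the compounds named here.

Compound 1 `Cc1ccc(S(=O)(=O)/C(=C/c2ccc(Cl)cc2)C(=O)c2ccc(Cl)cc2)cc1`: 1000 nM
Compound 2 `O=C(/C(=C\c1ccc(Cl)cc1)S(=O)(=O)c1ccc(Cl)cc1)c1ccc(Cl)cc1`: 25000 nM

In a functional assay on DU-145 cells (Homo sapiens) for inhibition, read by trypan blue exclusion, with a stated time of 96 h (a lower number here means a stronger inhibitor of growth, a higher number a weaker inhibitor of growth), compound 1 gives 1000 nM, the lower of the two numbers; its nearest neighbour is compound 2, and the step of a 25-fold higher number from compound 1 to compound 2 (1.40 log units; beyond the scatter) is large. Compound 3 `Cc1ccc(S(=O)(=O)/C(=C/c2c(O)cc(O)cc2O)C(=O)c2ccc(Cl)cc2)cc1` is not yet measured. Going by the values given here, it differs from compound 1 by 2,4,6-trihydroxyphenyl in place of 4-chlorophenyl on a double-bonded chain carbon bound to a double-bonded chain carbon, a change at a different place from the one measured step, which swapped chloro for methyl on an aromatic carbon. That step bears only loosely on the present change, but it shows that a single aromatic substituent can move this assay a great deal, so a sizeable shift in either direction is plausible. Among the compounds with values here, with no direct precedent, compound 3 is expected to be a weaker inhibitor than compound 1 by a modest margin, a 3.0-fold higher number from compound 1 to compound 3 (0.48 log units; beyond the scatter), giving an estimate of 3000 nM with a range from 600 nM to 15000 nM.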

Compound 3, concentration for 50% growth inhibition: > 100000 nM
Compound 3: a limit, no number; the forecaster's own chance of this, stated with the estimate: 10%; middle value at least 33-fold (1.52 log units) from the limit.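

In this assay, 2,4,6-trihydroxyphenyl in place of 4-chlorophenyl on a double-bonded chain carbon bound to a double-bonded chain carbon gives a large loss, an at least 100-fold higher number from compound 1 to compound 3 (2.00 log units; beyond the scatter). The earlier step, a 25-fold higher number from compound 1 to compound 2 (1.40 log units; beyond the scatter), concerned only chloro in place of methyl on an aromatic carbon, so this result adds a second place in the core of compound 1 where one change strongly weakens growth inhibition. Compound 3 gives > 100000 nM, which is a limit of the assay and not a number: the limit of > 100000 nM in this assay, at which 1 of the 3 values shown sits.

The change removes the chlorine and brings in the hydroxyl groups together, and the compounds shown cannot tell these two parts apart. From the compounds shown here alone, it remains open whether a phenyl, a 4-hydroxyphenyl or a 2,4,6-trimethoxyphenyl group at this place would keep the growth inhibition of compound 1.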